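The source may report more compounds than this note shows. Statements on the series, on what has been measured and on what is new or still open speak of the compounds shown alone.

Measured compounds:
compound 1 `Cc1cc(C)c(S(C)(=O)=O)cc1C(=O)N=C(N)N` — 11 nM
compound 2 `Cc1cc(C2CCC2)c(S(C)(=O)=O)cc1C(=O)N=C(N)N` — 8.2 nM
compound 3 `CSc1cc(C)c(C(=O)N=C(N)N)cc1S(C)(=O)=O` — 6 nM

In a functional assay for inhibition of sodium/hydrogen exchanger (Oryctolagus cuniculus) (a higher number here means a weaker inhibitor, a lower number a stronger inhibitor), compound 1 has the highest of the three numbers, yet a 1.3-fold lower number from compound 1 to compound 2 (0.13 log units; within the scatter) and a 1.8-fold lower number from compound 1 to compound 3 (0.26 log units; within the scatter) both stay within the scatter, as does a 1.4-fold lower number from compound 2 to compound 3 (0.14 log units; within the scatter). Compound 4 `Cc1ccc(C(=O)N=C(N)N)cc1S(C)(=O)=O` is not yet measured; it differs from compound 1 by hydrogen in place of methyl on an aromatic carbon. Going by the values given here, no measured step removes this methyl outright; the measured steps only exchange it for cyclobutyl or methylsulfanyl, and none of them leaves the scatter. Since exchanging the group at this carbon gave a 1.8-fold lower number from compound 1 to compound 3 (0.26 log units; within the scatter) at most, a step of similar size or none beyond the scatter is expected, most likely toward a slightly higher number. Compound 4 is therefore estimated at 15 nM, with a range of 6 nM to 40 nM. The expected step is a 1.4-fold higher number from compound 1 to compound 4 (0.13 log units; within the scatter).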

Compound 4, half-maximal inhibitory concentration: 210 nM
Estimate against measurement, compound 4: 14-fold (1.15 log units) below; the measured number lies above the stated range.
By their numbers in this assay, from the lowest: compounds 3, 2 and 1 (each within the scatter of the next); then compound 4.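

In this assay, removing the methyl gives a 19-fold higher number from compound 1 to compound 4 (1.28 log units; beyond the scatter), the only step among these compounds that leaves the scatter. The carbon ortho to the group of 6 heavy atoms and para to the methylsulfonyl group therefore does not tolerate every change: methyl, cyclobutyl and methylsulfanyl there stay within the scatter of each other, while hydrogen stands well apart. Nothing shown explains this drop.

From the compounds shown here alone, whether an amine, a chlorine atom or a methoxy group at this carbon would behave like methyl or like hydrogen remains open. So does whether a longer chain would still be accepted there.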